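From Hydroxymethyl to Carboxy: Expecting Compound 3

The compounds below may be only part of what the source reports. "The series", "measured", "known", "first", "only" and "open" are said of these compounds alone.

Compound 1, `CO[C@H]1C[C@H](O[Si](C)(C)C(C)(C)C)O[C@@H](C)/C1=C\C=N\O`: 0.002 ug/mL in a functional assay on the whole organism for inhibition, with Artemia salina as the target; on this read-out higher numbers stand for weaker inhibition of growth and lower numbers for stronger inhibition of growth
Compound 2, `CO[C@H]1C[C@H](O[Si](C)(C)C(C)(C)C)O[C@@H](C)/C1=C/CO`: 0.01 ug/mL

Of the two measured compounds, compound 2 stands at the highest number. In this assay compound 2 gives 0.01 ug/mL, while compound 1 gives 0.002 ug/mL, a gap beyond the usual scatter. Compound 3, `CO[C@H]1C[C@H](O[Si](C)(C)C(C)(C)C)O[C@@H](C)/C1=C/C(=O)O`, differs from compound 2 by carboxy in place of hydroxymethyl on a double-bonded chain carbon bound to a double-bonded ring carbon. Going by the values given here, no measured pair shows this change, so its size is not known from these data. Compound 3 is expected to give a higher number than compound 2, an expected step of a number 2.3 two-fold dilutions higher from compound 2 to compound 3 (beyond the scatter). The estimate for compound 3 is 0.05 ug/mL, with a range from 0.01 ug/mL to 0.5 ug/mL.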

Compound 3, minimum inhibitory concentration: 0.002 ug/mL
For compound 3 the middle estimate is 4.6 two-fold dilutions above the measured one; the measured number lies below the stated range.
By their numbers in this assay, from the lowest: compounds 1 and 3 (each within the scatter of the next); then compound 2.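

In this assay the position responds to this change: carboxy in place of hydroxymethyl gives a number 2.3 two-fold dilutions lower from compound 2 to compound 3 (beyond the scatter), a move toward stronger inhibition of growth. The carboxy compound 3 gives 0.002 ug/mL and thus stands within the scatter of the oxime-bearing compound 1 at 0.002 ug/mL, so two different groups at this position give matching numbers. No measurement shown here explains the step.

The compounds shown leave open whether a methyl ester or a primary amide in place of carboxy would keep this number. They also leave open whether a longer chain carrying carboxy would do so.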